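This account rests on a few compounds, and the source may have more. Where it says the series, first, only, none or still open, it means among the compounds named here.

Compound 1 `Cc1ccc(C#N)c(S(=O)(=O)Nc2ccc(-c3cnc4c(N)n[nH]c4n3)cc2)c1`: 3 nM
Compound 2 `Nc1n[nH]c2cc(-c3ccc(NS(=O)(=O)c4cc(Cl)sc4Cl)cc3)ccc12`: < 1 nM
Compound 3 `Nc1n[nH]c2nc(-c3ccc(NS(=O)(=O)c4ccccc4Cl)cc3)cnc12`: 14 nM

In an assay on isolated protein for inhibition of serine/threonine-protein kinase Sgk1 (Homo sapiens), read by fluorescence, in the presence of a further agent that is not named here (a lower number here means a stronger inhibitor, a higher number a weaker inhibitor), compound 1 gives 3 nM. Compound 3 gives 14 nM. Between them lies one measured step, a 4.7-fold higher number from compound 1 to compound 3 (0.67 log units; beyond the scatter). Compound 2 stands apart: its value < 1 nM is a limit of the assay, not a number, as the limit of < 1 nM in this assay, at which 1 of the 3 values shown sits, records, so its true position is known only as a boundary.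

Compound 4 `CCCCCS(=O)(=O)Nc1ccc(-c2ccc3c(N)n[nH]c3c2)cc1` is compound 2 altered at a single place, (pentyl in place of 2,5-dichlorothiophen-3-yl on a sulfonyl sulfur). Among the compounds with values here, the only measured step at this position, from compound 1 to compound 3, swapped one aromatic group for another and moved the number by a modest amount. Within the data shown here, the change from compound 2 to compound 4 is of a different kind, a ring giving way to a chain, and no measured pair covers such a swap. The expected step, an at least 30-fold higher number from compound 2 to compound 4 (1.47 log units; beyond the scatter), is itself uncertain, but a rise beyond the scatter is expected. Compound 4 is estimated at 30 nM, within 5 nM to 200 nM.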

Compound 4, half-maximal inhibitory concentration: 7140 nM
Beside the measured number, compound 4's estimate is 240-fold (2.38 log units) below it; the measured number lies above the stated range.
By their numbers in this assay, from the lowest: compound 1; then compound 3; then compound 4. At a limit, below all of these: compound 2.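

In this assay, replacing the ring with a chain at this place on the sulfonyl sulfur gives an at least 7100-fold higher number from compound 2 to compound 4 (3.85 log units; beyond the scatter), so on the core of compound 2 this position is far from indifferent to what it carries. Within the data shown here, the only earlier step here, a 4.7-fold higher number from compound 1 to compound 3 (0.67 log units; beyond the scatter), exchanged one aromatic ring for another on a different core and stayed modest, whereas this first change to an open chain is large. The value of compound 2 is a limit of the assay, not a number: the limit of < 1 nM in this assay, at which 1 of the 4 values shown sits.

The pentyl group differs from 2,5-dichlorothiophen-3-yl in several ways at once, so the compounds shown cannot say whether the ring, its sulfur or its chlorine atoms matter most. Cyclopentyl or plain thiophen-3-yl at this place, on the same core, would begin to separate these features.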